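Swapping the Carboxyphenyl Substituent in an Allosteric Modulator

A few compounds are considered here, and "the series" means these few. Any claim that something is new, unique, unknown or untested is made for them only; others in the source may bear on it.

Compound 2 `Cc1c(OCCCCOc2ccc(C(=O)O)cc2F)ccc(C(=O)CC(C)C)c1O` gives 67.7% in an assay on HEK293 cells for positive allosteric modulation of metabotropic glutamate receptor 3 (Rattus norvegicus), read by thallium flux, with a stated time of 2.5 min (on this read-out lower numbers stand for smaller maximal responses and higher numbers for larger maximal responses), the lower of the two numbers shown, though its gap to compound 1 `COc1cc(C(=O)O)ccc1OCCCCOc1ccc(C(=O)CC(C)C)c(O)c1C`, which gives 73.9% in this assay, lies within the usual scatter. Compound 3 `Cc1cc(OCCCCOc2ccc(C(=O)CC(C)C)c(O)c2C)ccc1C(=O)O` carries 4-carboxy-3-methylphenyl in place of 4-carboxy-2-fluorophenyl on an oxygen on a saturated carbon. Within the data shown here, the only measured step touching that ring, a number 6.2 percentage points lower from compound 1 to compound 2 (within the scatter), stayed within the scatter, so no step beyond the scatter is expected from this change either. Compound 3 is thus expected to reach 70% in this assay, between 58% and 82%. The expected shift is a number 2.3 percentage points higher from compound 2 to compound 3 (within the scatter).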

Compound 3, largest response reached (reported as percent of maximum), in percent of the reference or control that the assay uses: 41.9%
Beside the measured number, compound 3's estimate is 28.1 percentage points above it; the whole stated range lies above it.
By their numbers in this assay, from the lowest: compound 3; then compounds 2 and 1 (each within the scatter of the next).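

In this assay, among these compounds, the change of 4-carboxy-2-fluorophenyl to 4-carboxy-3-methylphenyl on an oxygen on a saturated carbon gives a number 25.8 percentage points lower from compound 2 to compound 3 (beyond the scatter) and is the only step here beyond the scatter. This shows that the largest response is sensitive to the substitution of this carboxyphenyl ring, which the earlier step of a number 6.2 percentage points lower from compound 1 to compound 2 (within the scatter) did not reveal. No measurement available here explains the drop.

Going by these compounds, it remains open whether the drop belongs to the methyl group itself or to the missing fluoro group. On these data alone, it is equally open how a chloro group or a tetrazole would fare on this ring.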